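The compounds below may be only part of what the source reports. "The series", "measured", "known", "first", "only" and "open" are said of these compounds alone.

Compound 1 `CCCC(=S)SCC(=O)c1ccc(OC)cc1` gives the lowest of the two numbers measured in an assay on HEK293 cells for inhibition of protein deacetylase HDAC6 (Homo sapiens) (a lower number here means a stronger inhibitor, a higher number a weaker inhibitor), compound 1 standing at 110 nM. Compound 2 `CCSC(=S)SCC(=O)c1ccc(C(=O)Nc2ccc(Cl)cc2)cc1` differs from it in more than one place; in this assay compound 2 gives 1450 nM, a weaker result by a margin beyond the usual scatter. Compound 3 `CCOC(=S)SCC(=O)c1ccc(OC)cc1` has not yet been measured. It differs from compound 1 in one place: ethoxy in place of propyl on a thiocarbonyl carbon. Within the data shown here, no measured pair isolates this change, so the expectation rests on compound 1 alone. A modest step toward a weaker inhibitor is expected, a 2.3-fold higher number from compound 1 to compound 3 (0.36 log units; beyond the scatter), near the edge of the scatter. For compound 3 the estimate is 250 nM, within 80 nM to 800 nM.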

Compound 3, half-maximal inhibitory concentration: 448 nM
Compound 3: the middle estimate sits 1.8-fold (0.25 log units) below what was measured, and the stated range covers the measured number.
By their numbers in this assay, from the lowest: compound 1; then compound 3; then compound 2.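

Among these compounds, at this thiocarbonyl carbon, whose other neighbour is sulfur, the first comparison confined to one place in this assay shows that the group held there matters: ethoxy in place of propyl gives a modest step toward a weaker inhibitor (a 4.1-fold higher number from compound 1 to compound 3 (0.61 log units; beyond the scatter)). Both groups have the same count of heavy atoms, so that count alone does not set the result here. Nothing measured here explains this step.

Going by these compounds, how an amine or a longer chain would fare at this position remains open. So does whether the step would carry over to a core other than that of compound 1.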